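Bromo to trifluoromethyl on the core of compound 3

A few compounds are considered here, and "the series" means these few. Any claim that something is new, unique, unknown or untested is made for them only; others in the source may bear on it.

In a functional assay on CCRF-CEM cells (Homo sapiens) for antiproliferative activity, read by cell counting, with a stated time of 72 h (on this read-out higher numbers stand for weaker inhibition and lower numbers for stronger inhibition), compound 1 `C#C[C@@]1(O)[C@@H](CO)O[C@@H](n2cnc3c(-c4ccc(OC)cc4)ncnc32)[C@@H]1O` gives > 250000 nM, which is a limit of the assay and not a number. Compound 2 `C#C[C@@]1(O)[C@@H](CO)O[C@@H](n2cnc3c(-c4ccc(Cl)cc4)ncnc32)[C@@H]1O` gives 124000 nM, while compound 3 `C#C[C@@]1(O)[C@@H](CO)O[C@@H](n2cc(Br)c3c(N)ncnc32)[C@@H]1O` gives 30 nM, the lowest number in the series. Compound 4 `C#C[C@@]1(O)[C@@H](CO)O[C@@H](n2cc(C(F)(F)F)c3c(N)ncnc32)[C@@H]1O` carries trifluoromethyl in place of bromo on an aromatic carbon. For the measured compounds named here, the only measured step, an at least 2.0-fold lower number from compound 1 to compound 2 (0.30 log units; that floor lies within the scatter), is chloro in place of methoxy at another place, so it sets no size for this swap. Any move is expected towards a higher number because compound 3 holds 30 nM, the lowest number seen. The expected step is a moderate one: a 5.0-fold higher number from compound 3 to compound 4 (0.70 log units; beyond the scatter). For compound 4 the estimate is 150 nM, with an expected range of 25 nM to 1500 nM.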

Compound 4, half-maximal inhibitory concentration: 360 nM
Compound 4: the middle estimate sits 2.4-fold (0.38 log units) below what was measured, within the range that was stated.
By their numbers in this assay, from the lowest: compound 3; then compound 4; then compound 2. At a limit, above all of these: compound 1.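

On an aromatic carbon of the five-membered aromatic ring, trifluoromethyl in place of bromo gives a 12-fold higher number from compound 3 to compound 4 (1.08 log units; beyond the scatter) in this assay, the first size measured for any swap at this position. The earlier step concerned another place, so only now is it clear that this position does not tolerate every group equally: a change here alone moves the number well beyond the scatter.

From the compounds shown here alone, whether an amine, a nitrile or a longer chain at this position would keep the number low remains open. Nothing shown bears on the cause of this step.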